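Two Fluorines in Place of One Bromine

This account rests on a few compounds, and the source may have more. Where it says the series, first, only, none or still open, it means among the compounds named here.

Compound 1 `O=S(=O)(/C=C/c1ccccc1)Cc1ccc(Nc2ncnc3ccccc23)cc1` reaches only a limit in a functional assay on PC-3 cells (Homo sapiens); a higher number here means a weaker inhibitor of growth, a lower number a stronger inhibitor of growth: compound 1 gives > 100000 nM, which is a limit of the assay rather than a number. Compound 2 `O=S(=O)(/C=C/c1ccc(Br)cc1)Cc1ccc(Nc2ncnc3ccccc23)cc1` carries bromo in place of hydrogen on an aromatic carbon, and in this assay compound 2 gives 42000 nM. That step is an at least 2.3-fold lower number from compound 1 to compound 2 (0.37 log units; beyond the scatter), the only step measured here, and it rests on (the limit of > 100000 nM in this assay, at which 1 of the 2 values shown sits), so compound 2 holds the only number shown. Compound 3 `O=S(=O)(/C=C/c1ccc(F)cc1F)Cc1ccc(Nc2ncnc3ccccc23)cc1` differs from compound 2 by 2,4-difluorophenyl in place of 4-bromophenyl on a double-bonded chain carbon bound to a double-bonded chain carbon. Going by the values given here, the single measured step bears on it only loosely: it shows that bromo in place of hydrogen lowered the number, but says nothing about two fluorines replacing a bromine. The account therefore expects compound 3 to land close to compound 2 or somewhat weaker, with a 1.7-fold higher number from compound 2 to compound 3 (0.22 log units; within the scatter). Compound 3 is estimated at 70000 nM, between 25000 nM and 200000 nM.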

Compound 3, concentration for 50% growth inhibition: > 100000 nM
Compound 3 gave a limit, no number (the forecaster's own chance of this, stated with the estimate: 35%); middle value at least 1.4-fold (0.15 log units) away from the limit.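

In this assay, 2,4-difluorophenyl in place of 4-bromophenyl gives an at least 2.3-fold higher number from compound 2 to compound 3 (0.37 log units; beyond the scatter) and so the gain seen with bromo does not carry over to the two fluorines. Halogen on this ring is thus not enough by itself: of the two halogen-bearing compounds, only compound 2, the bromo one, gives a number. The step between compound 1 and compound 3 cannot be read, because both of their values are limits of the assay: the limit of > 100000 nM in this assay, at which 2 of the 3 values shown sit.

The compounds shown leave open whether a chloro, a methoxy or a nitrile group in place of the bromo would give a number in this assay at all. Also open, as far as these compounds go, is how a carboxylic acid or an amine on this ring would compare with compound 2.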